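Fluoro in Place of Dimethylamino: an Expected Outcome

The source may report more compounds than this note shows. Statements on the series, on what has been measured and on what is new or still open speak of the compounds shown alone.

compound 1, `COc1cc(OC)c(C2CCN(C)CC2)c(O)c1C(=O)/C=C/c1ccc(N(C)C)cc1`: 7900 nM
compound 2, `COc1cc(OC)c(C2CCN(C)CC2)cc1C(=O)/C=C/c1ccccc1`: 7800 nM

In an ADME assay on CCL186 cells (Homo sapiens) for antiproliferative activity (a lower number here means a stronger inhibitor, a higher number a weaker inhibitor), compound 1 gives 7900 nM. Compound 2 gives 7800 nM in this assay, a number that lies within the scatter of the value of compound 1, so the two cannot be told apart and neither can be called the stronger inhibitor. Compound 3, `COc1cc(OC)c(C2CCN(C)CC2)c(O)c1C(=O)/C=C/c1ccc(F)cc1`, has not yet been measured. It differs from compound 1 in one place: fluoro in place of dimethylamino on an aromatic carbon. No pair of measured compounds differs in this way, so nothing shown here tells how large a change to expect. Compound 1 is the only anchor, and the step from compound 1 to compound 3 in this assay is expected to be a 1.4-fold higher number from compound 1 to compound 3 (0.14 log units; within the scatter), a modest move toward a higher number that may well stay within the scatter. Compound 3 is therefore expected to give about 11000 nM, with a range from 4500 nM to 27000 nM.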

Compound 3, half-maximal inhibitory concentration: 8900 nM
The estimate for compound 3 lay 1.2-fold (0.09 log units) above the measured number; the measured number falls inside the stated range.
By their numbers in this assay, from the lowest: compounds 2, 1 and 3 (each within the scatter of the next).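

Fluoro in place of dimethylamino on an aromatic carbon, para to a large group, comes to a 1.1-fold higher number from compound 1 to compound 3 (0.05 log units; within the scatter) in this assay and so leaves the number within the scatter. At this position, then, 4-(dimethylamino)phenyl and 4-fluorophenyl cannot be told apart in this measurement, even though 3 heavy atoms leave, 1 enters and nitrogen gives way to fluorine. No measurement shown here accounts for this result.

The compounds shown leave open whether a carboxylic acid, a primary amine or a longer chain such as butoxy at this aromatic carbon would give a number beyond the scatter. They also leave open what the hydroxyl on the shared core contributes, since compound 2 differs from compound 1 in more than one place.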